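A few compounds are considered here, and "the series" means these few. Any claim that something is new, unique, unknown or untested is made for them only; others in the source may bear on it.

The compounds share one core and differ only in the group carried on an amide-type nitrogen. Compound 1 `O=C(CSc1nc(Nc2ccccc2)c2ccccc2n1)Nc1ccccc1Br` carries a 2-bromophenyl there, and in a functional assay on PC-3 cells (Homo sapiens) for inhibition, read by MTT assay, with a stated time of 72 h (on this read-out lower numbers stand for stronger inhibition and higher numbers for weaker inhibition), compound 1 gives 19800 nM. Compound 2 `C=CC(=O)Nc1cccc(NC(=O)CSc2nc(Nc3ccccc3)c3ccccc3n2)c1` carries a 3-((vinylcarbonyl)amino)phenyl instead, and in this assay compound 2 gives 8740 nM. For the measured compounds named here, the only step measured so far is a 2.3-fold lower number from compound 1 to compound 2 (0.36 log units; beyond the scatter), so compound 2 stands at the lowest of the two numbers seen.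

Compound 3 `O=C(CSc1nc(Nc2ccccc2)c2ccccc2n1)Nc1ccc(F)cc1` is the next member, and it is not yet measured. Its change from compound 2 is 4-fluorophenyl in place of 3-((vinylcarbonyl)amino)phenyl on an amide-type nitrogen. Going by the values given here, no measured step covers this exact exchange; the one step that bears on it, a 2.3-fold lower number from compound 1 to compound 2 (0.36 log units; beyond the scatter), shows that swapping a halogenated phenyl for the 3-((vinylcarbonyl)amino)phenyl lowered the number by a modest amount. Compound 3 goes the other way, back to a halogenated phenyl, so a modest rise is expected rather than a fall, though compound 1 and compound 3 differ in which halogen is present and where it sits. In this assay compound 3 is therefore expected to give 15000 nM, between 6000 nM and 40000 nM, which would be a step of a 1.7-fold higher number from compound 2 to compound 3 (0.23 log units; within the scatter).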

Compound 3, half-maximal inhibitory concentration: 9560 nM
Compound 3: middle estimate off by 1.6-fold (0.20 log units), on the high side; measured number inside the range.
By their numbers in this assay, from the lowest: compounds 2 and 3 (each within the scatter of the next); then compound 1.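

In this assay, a 1.1-fold higher number from compound 2 to compound 3 (0.04 log units; within the scatter) means that the 4-fluorophenyl and the 3-((vinylcarbonyl)amino)phenyl on the amide-type nitrogen cannot be told apart, even though the entering group has fewer heavy atoms, no hydrogen-bond donor or acceptor, and no double bonds outside the aromatic ring. For the compounds shown here, the 3-((vinylcarbonyl)amino)phenyl is thus not the only group that reaches this level, and halogenated phenyls are not all alike here, since putting 4-fluorophenyl in place of 2-bromophenyl gives a 2.1-fold lower number from compound 1 to compound 3 (0.32 log units; beyond the scatter). No measurement at hand gives a reason for either step.

The compounds shown leave open whether the difference between the two halogenated phenyls follows from the halogen or from where it sits, since both change together from compound 1 to compound 3. They also leave open how an unsubstituted phenyl, a phenyl carrying an amine or a methoxy group, or an alkyl chain in place of the ring on this nitrogen would read in this assay.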